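Swapping ring stereocentres in a brominated cytotoxicity series

This account rests on a few compounds, and the source may have more. Where it says the series, first, only, none or still open, it means among the compounds named here.

Compound 1 `C=C1CC[C@H]2C(C)(C)[C@@H](Br)CC[C@]2(C)[C@@H]1Cc1cc(O)c(C=O)cc1O`: 4000 nM
Compound 2 `CC(=O)OC[C@H]1[C@@]2(C)CC[C@H](Br)C(C)(C)[C@H]2CC[C@]1(C)O`: > 100000 nM
Compound 3 `CC(=O)OC[C@@H]1[C@@]2(C)CC[C@H](Br)C(C)(C)[C@@H]2CC[C@@]1(C)O`: 40000 nM

In an ADME assay on MT2 cells (Homo sapiens) for cytotoxicity, read by XTT assay (a higher number here means that more compound is tolerated, a lower number that less compound is tolerated), compound 1 gives 4000 nM, the lowest number among the measured compounds; the nearest is compound 3 with 40000 nM. For compound 2 the value in this assay, > 100000 nM, is only a limit of the assay and not a number. Compound 4 `C=C1CC[C@@H]2C(C)(C)[C@@H](Br)CC[C@]2(C)[C@H]1Cc1cc(O)c(C=O)cc1O` has not yet been measured. It differs from compound 1 only in configuration: the two compounds have the same atoms and bonds and differ only in configuration as drawn: 2 of 4 stereo elements differ; a stereocentre at a saturated ring carbon is drawn R in compound 1 and S in compound 4; a stereocentre at a saturated ring carbon is drawn R in compound 1 and S in compound 4. Among the measured compounds shown here, the one measured step of this kind, an at least 2.5-fold lower number from compound 2 to compound 3 (0.39 log units; beyond the scatter), rests on the fact that compounds 2 and 3 differ only in the configuration as drawn and on (the limit of > 100000 nM in this assay, at which 1 of the 3 values shown sits). A configurational change therefore can move the number modestly, in either direction. Compound 4 is expected at 5000 nM, between 1500 nM and 16000 nM, a step of a 1.3-fold higher number from compound 1 to compound 4 (0.10 log units; within the scatter) that is expected to stay near the scatter.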

Compound 4, half-maximal cytotoxic concentration: 4000 nM
Beside the measured number, compound 4's estimate is 1.3-fold (0.10 log units) above it; the measured number falls inside the stated range.
By their numbers in this assay, from the lowest: compounds 1 and 4 (each within the scatter of the next); then compound 3. At a limit, above all of these: compound 2.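

In this assay, changing two of the four stereocentres while keeping every atom and bond gives no change at the digits printed from compound 1 to compound 4 (within the scatter). So in this series a change of configuration need not move the number, and this pair has a true number at both ends. The earlier configurational step, an at least 2.5-fold lower number from compound 2 to compound 3 (0.39 log units; beyond the scatter), rests in part on a limit: the limit of > 100000 nM in this assay, at which 1 of the 4 values shown sits.

From the compounds shown here alone, whether changing only one of these two stereocentres would behave the same way stays open. Also open, going by these compounds, is whether this insensitivity to configuration would hold with a carboxylic acid in place of the aldehyde.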